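A few compounds are considered here, and "the series" means these few. Any claim that something is new, unique, unknown or untested is made for them only; others in the source may bear on it.

Compound 2 `C=CCNC(=O)n1c(-c2ccc(OC)cc2)cc(=O)c2c(OC)cc(OC)cc21` is one of three compounds tested in a functional assay on KOPN-8 cells (Homo sapiens) for antiproliferative activity, with a stated time of 72 h; a lower number here means that less compound is needed, a higher number that more compound is needed for the effect. Within the data shown here, compound 2 gives 12000 nM, one of only two numbers recorded; compound 3 `COC(=O)c1cc(=O)c2c(OC)cc(OC)cc2n1S(=O)(=O)c1ccc(C)cc1` gives 6000 nM, and the gap between these two lies within the usual scatter. Compound 1 `COc1ccc(-c2cc(=O)c3c(OC)cc(OC)cc3n2Cc2ccccc2)cc1` reaches only a limit of the assay, > 17300 nM, and no number is known for it. The step of an at least 1.4-fold lower number from compound 1 to compound 2 (0.15 log units; that floor lies within the scatter) rests on that limit (the limit of > 17300 nM in this assay, at which 1 of the 3 values shown sits), and its floor sits within the scatter.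

Compound 4 `COc1ccc(-c2cc(=O)c3c(OC)cc(OC)cc3n2S(=O)(=O)Cc2ccccc2)cc1` has not yet been measured. It differs from compound 2 in one place: benzylsulfonyl in place of allylcarbamoyl on an aromatic nitrogen. Among the measured compounds shown here, the only measured step at this aromatic nitrogen is an at least 1.4-fold lower number from compound 1 to compound 2 (0.15 log units; that floor lies within the scatter), which is small and uncertain. Compound 3 also carries a sulfonyl group on an aromatic nitrogen, but it differs from compound 2 elsewhere as well, and no single step can be read from its value. The step of a 1.5-fold lower number from compound 2 to compound 4 (0.18 log units; within the scatter) is therefore expected to be small, within the scatter or little beyond it. Compound 4 is expected to give 8000 nM in this assay, within a range from 3000 nM to 20000 nM.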

Compound 4, half-maximal effective concentration: > 34400 nM
Compound 4 gave a limit, no number; the forecaster's own chance of this, stated with the estimate: 20%; middle value at least 4.3-fold (0.63 log units) from the limit.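

Among these compounds, the change at this aromatic nitrogen, benzylsulfonyl in place of allylcarbamoyl, gives the first step here that is larger than the scatter in this assay: an at least 2.8-fold higher number from compound 2 to compound 4 (0.45 log units; beyond the scatter). This shows that the group on this nitrogen can matter, which the earlier step at the same place could not show. Compound 4 stands at a limit of the assay, > 34400 nM, not at a number, and the step between compound 1 and compound 4 cannot be read, since both values are limits.

Still open, going by these compounds, is which part of the change counts: the sulfonyl link, the benzyl ring, or the loss of the amide hydrogen. Also open, on these data alone, is how a chain ending in an amine, or a carboxylic acid, on this nitrogen would behave in this assay.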